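A carbonate ester in place of a trifluoroethyl ester

The source may hold more compounds than are shown below. What is called first, only, known or untested is meant among the compounds shown, and "the series" means these compounds.

Compound 1 `C[C@@H](O)[C@H]1C(=O)N2C(C(=O)OCOC(=O)C3CCCCC3)=C(S[C@@H]3CN[C@H](C(=O)Nc4cccc(C(=O)O)c4)C3)[C@H](C)[C@H]12`: in an ADME assay for metabolic stability, read by LC-MS, with a stated time of 3 h, at pH 6.5, tested at 50 uM (on this read-out higher numbers stand for a more stable compound and lower numbers for a less stable compound), compound 1 gives > 95%, which is a limit of the assay.
Compound 2 `C[C@@H](O)[C@H]1C(=O)N2C(C(=O)OCC(F)(F)F)=C(S[C@@H]3CN[C@H](C(=O)Nc4cccc(C(=O)O)c4)C3)[C@H](C)[C@H]12`: in this assay compound 2 gives > 95%, again a limit of the assay.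
Compound 3 `C[C@@H](O)[C@H]1C(=O)N2C3=C(S[C@@H]4CN[C@@H](C4)C(=O)Nc4cccc(c4)C(=O)OCCCOC3=O)[C@H](C)[C@H]12`: in this assay compound 3 gives > 95%, also a limit of the assay.

Compound 2 therefore stands at the upper end of everything shown, and every value so far sits there (the limit of > 95% in this assay, at which 3 of the 3 values shown sit). Going by the values given here, the one measured step that touches the same part of the molecule, a step that the two limits leave unreadable from compound 1 to compound 2, has a limit at both ends, so its size cannot be read. Compound 4 `C[C@@H](O)[C@H]1C(=O)N2C(C(=O)OCOC(=O)OC(C)(C)C)=C(S[C@@H]3CN[C@H](C(=O)Nc4cccc(C(=O)O)c4)C3)[C@H](C)[C@H]12` differs from compound 2 by (tert-butoxycarbonyl)oxy in place of trifluoromethyl on a saturated chain carbon bound to an oxygen next to a carbonyl group. The measured steps give no size at all for a change of this kind, and all three compounds share the same limit, so there is no basis for a step beyond the scatter. In this assay the step from compound 2 to compound 4 is expected to be a number no higher from compound 2 to compound 4 (the limit leaves the size open). Compound 4 is expected to give 95% in this assay, with a range from 85% to 100%, most probably reported again only as a limit.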

Compound 4, percent of the compound remaining: > 95%
Compound 4: no number, only a limit; the forecaster's own chance of this, stated with the estimate: 80%; the middle value sits exactly at the limit.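

In this assay compound 4 gives > 95%, a limit of the assay. The steps between compound 1, compound 2 and compound 4 therefore cannot be read: the limit of > 95% in this assay, at which 4 of the 4 values shown sit. The compounds shown leave open whether exchanging these groups changes the percent remaining at all.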